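Working notes on the morpholinyl to pyrrolidinyl step

The source may report more compounds than this note shows. Statements on the series, on what has been measured and on what is new or still open speak of the compounds shown alone.

Measured so far, half-maximal inhibitory concentration in a functional assay on HeLa cells (Homo sapiens) for cytotoxicity, read by MTT assay, with a stated time of 72 h; on this read-out higher numbers stand for weaker inhibition and lower numbers for stronger inhibition:
compound 1 `N/C(=N\NC(=S)N1CCOCC1)c1ccccn1`: 7300 nM
compound 2 `Cc1ccnc(/C(N)=N/NC(=S)N2CCOCC2)c1`: 38500 nM
compound 3 `Cc1cccc(/C(N)=N/NC(=S)N2CCOCC2)n1`: 2200 nM

Compound 2 gives the highest number of the three. The step of a 5.3-fold higher number from compound 1 to compound 2 (0.72 log units; beyond the scatter) raises the number, whereas a 3.3-fold lower number from compound 1 to compound 3 (0.52 log units; beyond the scatter) lowers it, so compound 2 stands furthest from compound 3, which gives the lowest number.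

Compound 4 `Cc1ccnc(/C(N)=N/NC(=S)N2CCCC2)c1` is not yet measured. It differs from compound 2 by pyrrolidin-1-yl in place of morpholin-4-yl on a thiocarbonyl carbon. Among the measured compounds shown here, both measured steps concern a methyl on an aromatic carbon; neither touches the thiocarbonyl side, so no measured step bears on this change. With no guidance, no step beyond the scatter is expected in this assay, and the expected step from compound 2 is no change at the digits printed from compound 2 to compound 4 (within the scatter). Compound 4 is therefore estimated at 38500 nM, with a range from 12000 nM to 120000 nM.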

Compound 4, half-maximal inhibitory concentration: 1900 nM
Estimate against measurement, compound 4: 20-fold (1.31 log units) above, outside the stated range (below it).
By their numbers in this assay, from the lowest: compounds 4 and 3 (each within the scatter of the next); then compound 1; then compound 2.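

The thiocarbonyl carbon responds more strongly than any aromatic carbon examined so far: in this assay pyrrolidin-1-yl in place of morpholin-4-yl gives a 20-fold lower number from compound 2 to compound 4 (1.31 log units; beyond the scatter) and this step exceeds both methyl steps. Morpholin-4-yl carries an oxygen and pyrrolidin-1-yl does not, but the two groups also differ in ring size, and this single pair cannot separate the two differences. Nothing available accounts for the size of this step.

Open, as far as these compounds go, is whether piperidin-1-yl or dimethylamino on the thiocarbonyl carbon would separate ring size from the oxygen, and whether pyrrolidin-1-yl gives a similar step on the core of compound 1 or compound 3.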